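The source may hold more compounds than are shown below. What is called first, only, known or untested is meant among the compounds shown, and "the series" means these compounds.

Measured compounds:
Compound 1 `COc1cc(C(=O)c2cn(-c3cccc(C)c3)cc2-c2ccccc2[N+](=O)[O-])cc(OC)c1OC` gives 220 nM in a functional assay on MCF7 cells (Homo sapiens) for cytotoxicity, read by MTT assay, with a stated time of 96 h; a lower number here means a stronger inhibitor, a higher number a weaker inhibitor.
Compound 2 `COc1cc(C(=O)c2cn(-c3cccc(C)c3)cc2-c2cccc([N+](=O)[O-])c2)cc(OC)c1OC` gives 880 nM in this assay.
Compound 3 `COc1cc(C(=O)c2cn(-c3ccc(N)cc3)cc2-c2ccccc2[N+](=O)[O-])cc(OC)c1OC` gives 53 nM in this assay.

These three share a core, and compound 4 `COc1cc(C(=O)c2cn(-c3ccc(N)cc3)cc2-c2cccc([N+](=O)[O-])c2)cc(OC)c1OC` has not yet been measured in this assay. Among the measured compounds, compound 3 stands lowest: the nearest step is a 4.2-fold lower number from compound 1 to compound 3 (0.62 log units; beyond the scatter), and compound 2 lies further away still. The core of compound 1 and the core of compound 3 differ in one place: 4-aminophenyl in place of 3-methylphenyl on an aromatic nitrogen.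

The change that leads from compound 3 to compound 4 is 3-nitrophenyl in place of 2-nitrophenyl on an aromatic carbon. The same kind of change has already been made once, from compound 1 to compound 2, where it is 3-nitrophenyl in place of 2-nitrophenyl on an aromatic carbon. That step was a 4.0-fold higher number from compound 1 to compound 2 (0.60 log units; beyond the scatter). The two places are not the same word for word: in one the nearby ring atom bears a 3-methylphenyl group, in the other a 4-aminophenyl group, so it is the same kind of change rather than the same change.

Among the measured compounds shown here, with only one earlier example of this change, the expectation for compound 4 rests on that single step. Compound 4 is expected to give 210 nM in this assay, somewhere between 80 nM and 550 nM, because compound 3 gives 53 nM and the earlier step was a 4.0-fold higher number from compound 1 to compound 2 (0.60 log units; beyond the scatter). This means an expected step of a 4.0-fold higher number from compound 3 to compound 4 (0.60 log units; beyond the scatter).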

Compound 4, half-maximal inhibitory concentration: 260 nM
The estimate for compound 4 lay 1.2-fold (0.09 log units) below the measured number; the measured number falls inside the stated range.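

Swapping 2-nitrophenyl for 3-nitrophenyl in this assay gives a 4.9-fold higher number from compound 3 to compound 4 (0.69 log units; beyond the scatter), and this is close to what the same swap did on the core that carries 3-methylphenyl on the ring nitrogen: the same change on two cores in this assay, a 4.0-fold higher number (0.60 log units; beyond the scatter) from compound 1 to compound 2 and a 4.9-fold higher number (0.69 log units; beyond the scatter) from compound 3 to compound 4, 1.2-fold (0.09 log units) apart, within the scatter of two such steps. The other change in this set, 4-aminophenyl in place of 3-methylphenyl on the ring nitrogen, also carries over, with a 3.4-fold lower number from compound 2 to compound 4 (0.53 log units; beyond the scatter) on the core that carries 3-nitrophenyl: the same change on two cores in this assay, a 4.2-fold lower number (0.62 log units; beyond the scatter) from compound 1 to compound 3 and a 3.4-fold lower number (0.53 log units; beyond the scatter) from compound 2 to compound 4, 1.2-fold (0.09 log units) apart, within the scatter of two such steps. Across these compounds, then, each change keeps its size whichever form of the other group is present, but this is a single square of compounds in one cell assay, so it does not show that the same holds for other groups or explain why either change alters the number.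

The compounds shown leave open whether the step between the two phenyl positions stays the same size when the nitro group is replaced by another group, such as an amine or a nitrile. They also leave open whether the steps would hold with something other than a substituted phenyl ring on the ring nitrogen, such as a butyl chain.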